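Selenium for sulfur on an isothiourea-type linker

The compounds below may be only part of what the source reports. "The series", "measured", "known", "first", "only" and "open" are said of these compounds alone.

The series pairs two acylated imidate-like linkers. Compound 1 `CS/C(=N\C(=O)c1ccno1)NC(=O)c1ccno1` carries small five-membered heteroaryl amides on both ends, while compound 2 `CS/C(=N\C(=O)c1cc(-c2ccccc2)nc2ccccc12)NC(=O)c1cc(-c2ccccc2)nc2ccccc12` carries two larger bicyclic aryl amides. In a functional assay on HT-29 cells (Homo sapiens) for cytotoxicity, read by MTT assay, with a stated time of 72 h (a lower number here means that less compound is tolerated, a higher number that more compound is tolerated), compound 1 reaches only the limit of > 100000 nM. In this assay compound 2 likewise reaches only the limit of > 100000 nM. Within the data shown here, compound 2 thus stands at the ceiling of what was tested, a position it shares with compound 1, as the single piece of evidence shows (the limit of > 100000 nM in this assay, at which 2 of the 2 values shown sit).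

Compound 3 `C[Se]/C(=N\C(=O)c1cc(-c2ccccc2)nc2ccccc12)NC(=O)c1cc(-c2ccccc2)nc2ccccc12` differs from compound 2 in one place (a group of 2 heavy atoms (1 carbon, 1 selenium; no ring) in place of a group of 2 heavy atoms (1 carbon, 1 sulfur; no ring), on a carbon with a double bond to nitrogen). Among the measured compounds shown here, with no measured step between any two compounds, the expected step from compound 2 to compound 3 in this assay is modest, toward somewhat less compound tolerated, though a further limit remains possible. Compound 3 is therefore estimated at 70000 nM, with a range from 15000 nM to 200000 nM, an expected shift of an at least 1.4-fold lower number from compound 2 to compound 3 (0.15 log units; that floor lies within the scatter).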

Compound 3, concentration lethal to 50% of the cells: 90700 nM
Beside the measured number, compound 3's estimate is 1.3-fold (0.11 log units) below it, and the stated range covers the measured number.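

Selenium in place of the sulfur of methylsulfanyl, on a carbon with a double bond to nitrogen, gives the first value in this assay that is a number and not a limit: compound 3 gives 90700 nM. From the compounds shown here alone, the step is an at least 1.1-fold lower number from compound 2 to compound 3 (0.04 log units; that floor lies within the scatter), and as compound 2 holds only a limit, its true size stays unknown, so the data fit no real change as well as a larger one. Even so, the limit still marks most of this small set: the limit of > 100000 nM in this assay, at which 2 of the 3 values shown sit.

Going by these compounds, it remains open whether an amine or a longer chain in place of the methylsulfanyl on this carbon would give a number in this assay. On these data alone, it is also open whether selenium would do the same with the small amides of compound 1.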